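Series notes: thian, piperidine, cyclohexyl to oxane on the chain amine

This account rests on a few compounds, and the source may have more. Where it says the series, first, only, none or still open, it means among the compounds named here.

Measured compounds in a functional assay on cells for agonist activity at C-X-C chemokine receptor type 4 (Homo sapiens), read by fluorescence and calcium flux, with a stated time of 90 s; on this read-out higher numbers stand for an effect only at larger amounts of compound and lower numbers for an effect already at smaller amounts:
compound 1 `c1ccc2c(c1)CN[C@@H](CN(CCCCNCC1CCNCC1)[C@H]1CCCc3cccnc31)C2`: > 30000 nM, a limit of the assay
compound 2 `c1ccc2c(c1)CN[C@@H](CN(CCCCNCC1CCSCC1)[C@H]1CCCc3cccnc31)C2`: > 30000 nM, a limit of the assay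
compound 3 `c1ccc2c(c1)CN[C@@H](CN(CCCCNC1CCCCC1)[C@H]1CCCc3cccnc31)C2`: > 30000 nM, a limit of the assay

Compound 3 therefore stands at the assay limit, as do the two other measured compounds; no number is known for any of them. The steps a step that the two limits leave unreadable from compound 1 to compound 2, a step that the two limits leave unreadable from compound 1 to compound 3 and a step that the two limits leave unreadable from compound 2 to compound 3 are all unreadable, since both ends of each sit at the limit of > 30000 nM in this assay, at which 3 of the 3 values shown sit.

Compound 4 `c1ccc2c(c1)CN[C@@H](CN(CCCCNC1CCOCC1)[C@H]1CCCc3cccnc31)C2` differs from compound 3 by oxan-4-yl in place of cyclohexyl on an amine nitrogen. For the measured compounds named here, no measured step bears on this change in a readable way; the three measured steps only show that exchanging the ring on the chain amine nitrogen has not moved any compound off the limit. The step that the limit leaves unreadable from compound 3 to compound 4 is therefore expected to leave compound 4 at the limit as well, with no direction readable. For compound 4 the estimate in this assay is 45000 nM, with a range from 15000 nM to 150000 nM.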

Compound 4, half-maximal effective concentration: > 30000 nM
Compound 4: a limit, no number; the forecaster's own chance of this, stated with the estimate: 85%; the middle value is on the limit's open side.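

No step linking compound 4 with compound 1, compound 2 or compound 3 can be read, because all four share one limit: the limit of > 30000 nM in this assay, at which 4 of the 4 values shown sit.

The compounds shown leave open how the four rank and whether exchanging the ring on the chain amine nitrogen changes the read-out at all.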